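The compounds below may be only part of what the source reports. "The series", "measured", "known", "first", "only" and "open" are said of these compounds alone.

Compound 1 `Oc1ccccc1-c1cc(-c2cccs2)cc(-c2ccccc2O)n1` gives in a functional assay on T47D cells (Homo sapiens) for cytotoxicity, read by CCK-8 assay (a lower number here means a stronger inhibitor, a higher number a weaker inhibitor), only a limit of the assay, > 50000 nM.
Compound 2 `Oc1ccccc1-c1cc(-c2ccoc2)cc(-c2ccccc2O)n1` gives in this assay likewise only a limit, > 50000 nM.

Compound 2 thus stands at the assay limit, with no number of its own, and the step that the two limits leave unreadable from compound 1 to compound 2 cannot be read for size. Compound 3 `Oc1ccccc1-c1cc(-c2ccccn2)cc(-c2ccccc2O)n1` differs from compound 2 in one place: pyridin-2-yl in place of furan-3-yl on an aromatic carbon. Going by the values given here, the only measured step bearing on this change is unreadable, and both values sit at the limit of > 50000 nM in this assay, at which 2 of the 2 values shown sit. No step beyond the scatter is therefore expected, and compound 3 is estimated at 60000 nM (range 20000 nM to 200000 nM), meaning an expected step that the limit leaves unreadable from compound 2 to compound 3.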

Compound 3, half-maximal inhibitory concentration: > 50000 nM
Compound 3: a limit, no number; the forecaster's own chance of this, stated with the estimate: 85%; the middle value does not contradict the limit.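

Going by these compounds alone, compound 3 also gives only a limit in this assay, so no step among compound 1, compound 2 and compound 3 can be read for size. Whether these three compounds differ in strength at all stays open, because all of them sit at the same limit: the limit of > 50000 nM in this assay, at which 3 of the 3 values shown sit.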